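Swapping the piperazine substituent: from aryl to 3-fluorobenzyl

A few compounds are considered here, and "the series" means these few. Any claim that something is new, unique, unknown or untested is made for them only; others in the source may bear on it.

Three compounds share a core and were tested in a functional assay on Mahlavu cells (Homo sapiens) for antiproliferative activity, read by sulforhodamine B assay, with a stated time of 72 h; a lower number here means a stronger inhibitor, a higher number a weaker inhibitor. Compound 1 `Cc1cccc(COc2ccc(-c3cc(CN4CCN(Cc5ccc(C(F)(F)F)cc5)CC4)no3)cc2)c1` gives 2500 nM. Compound 2 `FC(F)(F)c1ccc(CN2CCN(Cc3cc(-c4ccc(OCc5cccc(Cl)c5)cc4)on3)CC2)cc1` gives 4100 nM; the step of a 1.6-fold higher number from compound 1 to compound 2 (0.21 log units; within the scatter) changes only the benzyloxy ring. Compound 3 `N#Cc1cccc(COc2ccc(-c3cc(CN4CCN(c5ccc(C(F)(F)F)cc5)CC4)no3)cc2)c1` gives 2700 nM, a value that sits within the scatter of both compound 1 and compound 2, so the three cannot be told apart on these numbers.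

Compound 4 `N#Cc1cccc(COc2ccc(-c3cc(CN4CCN(Cc5cccc(F)c5)CC4)no3)cc2)c1` differs from compound 3 by 3-fluorobenzyl in place of 4-(trifluoromethyl)phenyl on an amine nitrogen in a ring. Going by the values given here, no measured step touches that ring nitrogen directly. Among the compounds with values here, the only step on record, from compound 1 to compound 2, lies elsewhere and stays within the scatter. Still, compound 1 and compound 2 both carry a benzyl-type group on that same amine nitrogen in a ring, and their values match that of compound 3, which carries the phenyl directly. For compound 4 the expected step of no change at the digits printed from compound 3 to compound 4 (within the scatter) is therefore none beyond the scatter. Compound 4 is estimated at 2700 nM, with a range from 1200 nM to 6000 nM in this assay.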

Compound 4, half-maximal inhibitory concentration: 2600 nM
Estimate against measurement, compound 4: 1.0-fold (0.02 log units) above; measured number inside the range.
By their numbers in this assay, from the lowest: compounds 1, 4, 3 and 2 (each within the scatter of the next).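

In this assay, replacing 4-(trifluoromethyl)phenyl with 3-fluorobenzyl on the amine nitrogen gives a 1.0-fold lower number from compound 3 to compound 4 (0.02 log units; within the scatter), so no difference between these two groups can be read. This is the first pair shown that differs only at this nitrogen, and it shows that two different groups, each with one carbon-only aromatic ring, can occupy this position with no measurable effect on the read-out. No measurement is available to explain why the two compounds read alike.

Going by these compounds, both groups compared here are uncharged and built around an aromatic ring, so it remains open how a small methyl group, or a chain ending in a carboxylic acid or an amine, would behave at this nitrogen. On these data alone, it is also open whether an acetyl group, which would turn this nitrogen into an amide, would leave the value unchanged.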